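From dimethylamino to pyrrolidin-1-yl: what to expect

This account rests on a few compounds, and the source may have more. Where it says the series, first, only, none or still open, it means among the compounds named here.

- compound 1 `CN(C)c1ccc2cc(-c3ccccc3F)c(N)nc2c1` gives 1600 nM as its value
- compound 2 `CN(C)c1ccc2cc(-c3cn(C)c4ccccc34)c(N)nc2c1` gives 3700 nM as its value

Both were measured in a toxicity assay on J774.A1 cells (Mus musculus) for cytotoxicity, read by SYBR Green assay, with a stated time of 1 h (on this read-out lower numbers stand for an effect already at smaller amounts and higher numbers for an effect only at larger amounts of compound), and compound 2 has the higher number of the two, with a gap to compound 1 that lies beyond the scatter. Compound 3 `Cn1cc(-c2cc3ccc(N4CCCC4)cc3nc2N)c2ccccc21` has pyrrolidin-1-yl in place of dimethylamino on an aromatic carbon and is otherwise the same as compound 2. Going by the values given here, no measured pair shows this change, so only a slight downward move in this assay is expected, within the scatter. The expected move is a 1.2-fold lower number from compound 2 to compound 3 (0.09 log units; within the scatter) in size. For compound 3 the estimated value is 3000 nM (expected range 1200 nM to 7000 nM) until the measurement is known.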

Compound 3, half-maximal effective concentration: 440 nM
Compound 3: middle estimate off by 6.8-fold (0.83 log units), on the high side; measured number below the stated range.
By their numbers in this assay, from the lowest: compound 3; then compound 1; then compound 2.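

Placing pyrrolidin-1-yl in place of dimethylamino on this aromatic carbon makes a clear difference in this assay, giving an 8.4-fold lower number from compound 2 to compound 3 (0.92 log units; beyond the scatter). Going by these compounds alone, until now, no pair of compounds had tested this position, and this one shows that the number responds to a change there, even though the two groups differ only by a ring and two extra carbons. Nothing at hand explains the size of this step.

Going by these compounds, whether piperidin-1-yl, morpholin-4-yl or diethylamino would move the number further remains open. So does whether the same exchange on the core of compound 1 would give a similar step.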